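This account rests on a few compounds, and the source may have more. Where it says the series, first, only, none or still open, it means among the compounds named here.

Of the compounds shown here, two have been tested in a toxicity assay on Vero C1008 cells (Chlorocebus sabaeus) for cytotoxicity, read by neutral red uptake, with a stated time of 5 days; a lower number here means that less compound is tolerated, a higher number that more compound is tolerated. Compound 1 `CC(C)(C)c1ccc(N(C(=O)c2ccco2)C(C(=O)NC2CCCC2)c2cccnc2)cc1` gives 101000 nM, and compound 2 `CC(C)(C)CC(C)(C)NC(=O)C(c1cccnc1)N(C(=O)c1ccco1)c1ccc(-c2ccccc2)cc1` gives 148000 nM in this assay, a value that sits within the usual scatter of compound 1, so the two cannot be told apart. Compound 3 `O=C(NC1CCCC1)C(c1cccnc1)N(C(=O)c1ccco1)c1ccc(-c2ccccc2)cc1` is compound 2 with one change: cyclopentyl in place of 1,1,3,3-tetramethylbutyl on an amide-type nitrogen. Within the data shown here, with no measured step to lean on, the expected step from compound 2 to compound 3 in this assay, a 1.2-fold lower number from compound 2 to compound 3 (0.09 log units; within the scatter), is no change beyond the scatter. Compound 3 is therefore estimated at 120000 nM, with a range of 60000 nM to 250000 nM.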

Compound 3, half-maximal cytotoxic concentration: > 200000 nM
Compound 3: no number, only a limit; the forecaster's own chance of this, stated with the estimate: 10%; middle value at least 1.6-fold (0.22 log units) from the limit.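

In this assay, compound 3 carries a limit of the assay, not a number: the limit of > 200000 nM in this assay, at which 1 of the 3 values shown sits. Cyclopentyl in place of 1,1,3,3-tetramethylbutyl on the amide-type nitrogen gives an at least 1.3-fold higher number from compound 2 to compound 3 (0.13 log units; that floor lies within the scatter), and phenyl in place of tert-butyl on an aromatic carbon gives an at least 1.9-fold higher number from compound 1 to compound 3 (0.29 log units; that floor lies within the scatter). Both floors lie within the scatter, so neither change is shown to matter, yet neither lowers the number, and the true steps could be larger. Going by these compounds, how far compound 3 lies past its limit stays open, as does whether a chain carrying an amine or a carboxylic acid on that nitrogen would be tolerated equally well.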